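Sulfonyl aryl variation in a benzoxazole sulfonamide series

The source may hold more compounds than are shown below. What is called first, only, known or untested is meant among the compounds shown, and "the series" means these compounds.

Compound 3 `COc1ccccc1S(=O)(=O)Nc1ccc2oc(-c3ccccc3)nc2c1` carries a 2-methoxyphenyl on the sulfonyl sulfur. In an assay on cells for inhibition of HSP60/HSP10 (Homo sapiens), with a stated time of 60 min (on this read-out lower numbers stand for stronger inhibition and higher numbers for weaker inhibition), compound 3 gives > 100000 nM, which is a limit of the assay and not a number. Compound 1 `Cc1ccc(S(=O)(=O)Nc2ccc3oc(-c4ccccc4)nc3c2)cc1`, with 4-methylphenyl on the sulfonyl sulfur, gives > 100000 nM in this assay, again a limit. Compound 2 `O=S(=O)(Nc1ccc2oc(-c3ccccc3)nc2c1)c1cccc(Cl)c1`, with 3-chlorophenyl at that place, gives > 100000 nM in this assay, also a limit. The three steps among them, a step that the two limits leave unreadable from compound 1 to compound 2, a step that the two limits leave unreadable from compound 1 to compound 3 and a step that the two limits leave unreadable from compound 2 to compound 3, therefore carry no readable size; all three values sit at the limit of > 100000 nM in this assay, at which 3 of the 3 values shown sit.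

Compound 4 `O=S(=O)(Nc1ccc2oc(-c3ccccc3)nc2c1)c1cccs1` is not yet measured. It differs from compound 3 in one place: thiophen-2-yl in place of 2-methoxyphenyl on a sulfonyl sulfur. Within the data shown here, the measured steps bear on it only in that every aryl variation on the sulfonyl sulfur so far has left the value at the limit; no step of readable size exists to scale this change. The expected step from compound 3 to compound 4 is therefore a number no higher from compound 3 to compound 4 (the limit leaves the size open), with no direction beyond the scatter. Compound 4 is expected to give about 100000 nM in this assay, between 20000 nM and 500000 nM, most likely again reported only as a limit.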

Compound 4, half-maximal inhibitory concentration: 90000 nM
Compound 4: the middle estimate sits 1.1-fold (0.05 log units) above what was measured, and the stated range covers the measured number.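

In this assay, among these compounds, thiophen-2-yl is the first group on the sulfonyl sulfur in this set to give a number and not a limit. The steps of an at least 1.1-fold lower number from compound 3 to compound 4 (0.04 log units; that floor lies within the scatter) and an at least 1.1-fold lower number from compound 2 to compound 4 (0.04 log units; that floor lies within the scatter) and an at least 1.1-fold lower number from compound 1 to compound 4 (0.04 log units; that floor lies within the scatter) are floors only, so a real separation of thiophen-2-yl from the three six-membered aryl groups is neither shown nor excluded. This place on the sulfonyl sulfur now has one readable value, but the set still rests mainly on limits: the limit of > 100000 nM in this assay, at which 3 of the 4 values shown sit.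

Going by these compounds, whether an amine or a carboxylic acid on the thiophene ring, or a pyridine ring in its stead, would bring the value well clear of the limit stays open. Also open, on these data alone, is whether any change to the shared core would do so.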